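Working notes on a fluoro step in the series

The source may report more compounds than this note shows. Statements on the series, on what has been measured and on what is new or still open speak of the compounds shown alone.

Measured in an assay on U2OS cells for activation of nuclear factor erythroid 2-related factor 2 (Homo sapiens), read by chemiluminescence, with a stated time of 6 h; on this read-out higher numbers stand for an effect only at larger amounts of compound and lower numbers for an effect already at smaller amounts:
compound 1 `COc1ccccc1S(=O)(=O)/C=C/c1ccccn1` gives 9070 nM
compound 2 `COc1ccccc1S(=O)(=O)/C=C/c1ncccc1F` gives 877 nM
compound 3 `COc1ccc(S(=O)(=O)/C=C/c2ccccn2)cc1` gives > 10000 nM

Compound 1 and compound 3 are built from the same atoms joined differently; the difference between the two cores is not broken down here. For compound 3 the reading is a limit of this assay, not a number (the limit of > 10000 nM in this assay, at which 1 of the 3 values shown sits). Compound 2 differs from compound 1 in one place: fluoro in place of hydrogen on an aromatic carbon. That change gave a 10-fold lower number from compound 1 to compound 2 (1.01 log units; beyond the scatter).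

Compound 4 `COc1ccc(S(=O)(=O)/C=C/c2ncccc2F)cc1` has not been measured in this assay. Against compound 3 it carries fluoro in place of hydrogen on an aromatic carbon, the same change as from compound 1 to compound 2, at a place described in the same words. A single measured step cannot set a pattern, and compound 3 starts from a limit, so its starting point is itself uncertain. Should the step repeat, the expectation is an at least 3.3-fold lower number from compound 3 to compound 4 (0.52 log units; beyond the scatter), resting on compound 2 with a 10-fold lower number from compound 1 to compound 2 (1.01 log units; beyond the scatter). Compound 4 is therefore estimated near 3000 nM, most likely between 800 nM and 10000 nM, with a real chance that this assay again reports only a limit.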

Compound 4, half-maximal effective concentration: 1080 nM
Beside the measured number, compound 4's estimate is 2.8-fold (0.44 log units) above it; the measured number falls inside the stated range.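

In this assay, fluoro in place of hydrogen on an aromatic carbon of the six-membered aromatic ring with 1 nitrogen gave an at least 9.2-fold lower number from compound 3 to compound 4 (0.96 log units; beyond the scatter). Set beside the earlier step, the change points the same way on both cores: the same change on two cores in this assay, a 10-fold lower number (1.01 log units; beyond the scatter) from compound 1 to compound 2 and an at least 9.2-fold lower number (0.96 log units; beyond the scatter) from compound 3 to compound 4; the limit leaves it open whether they differ

For compound 3 the reading > 10000 nM is a limit of the assay and not a number, so the size of the step on this core stays unsettled, and two cores support a shared direction for these compounds only, not a rule for the series.

Whether chloro, a nitrile or an amine at the same place would also give a lower number remains open, since fluoro is the only group shown there. Also open, on these data alone, is whether the fluoro step would carry over to a core in which a carboxylic acid or a longer chain takes the place of the methoxy group.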